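Swapping the benzodioxinyl group for a trifluoromethylphenyl group

A few compounds are considered here, and "the series" means these few. Any claim that something is new, unique, unknown or untested is made for them only; others in the source may bear on it.

Of the compounds shown here, three sharing one core have been measured in a functional assay on HPAC cells (Homo sapiens) for inhibition, read by MTT assay, with a stated time of 72 h; a lower number here means a stronger inhibitor of growth, a higher number a weaker inhibitor of growth. Compound 1 `O=S(=O)(NCCCNCc1ccccc1Cl)c1cc(C(F)(F)F)cc(C(F)(F)F)c1` gives 10000 nM. Compound 2 `COc1ccc(CNCCCNS(=O)(=O)c2cc(C(F)(F)F)cc(C(F)(F)F)c2)cc1OC` gives 3500 nM, and compound 3 `O=S(=O)(NCCCNCC1COc2ccccc2O1)c1cc(C(F)(F)F)cc(C(F)(F)F)c1` gives 2700 nM, the lowest of the three numbers. The step of a 3.7-fold lower number from compound 1 to compound 3 (0.57 log units; beyond the scatter) is modest but beyond the scatter, as is a 2.9-fold lower number from compound 1 to compound 2 (0.46 log units; beyond the scatter), whereas a 1.3-fold lower number from compound 2 to compound 3 (0.11 log units; within the scatter) stays within the scatter. Compound 4 `O=S(=O)(NCCCNCc1ccc(C(F)(F)F)cc1)c1cc(C(F)(F)F)cc(C(F)(F)F)c1` is not yet measured. It differs from compound 3 in one place: 4-(trifluoromethyl)phenyl in place of 2,3-dihydro-1,4-benzodioxin-2-yl on a saturated chain carbon bound to an amine nitrogen. Among the measured compounds shown here, no measured step matches this change directly. The nearest guide is the step from compound 1 to compound 3, since compound 4, like compound 1, carries a plain aromatic ring without the two oxygen atoms of compound 3. The expectation is therefore a modest move back toward the number of compound 1, giving a step of about a 2.0-fold higher number from compound 3 to compound 4 (0.31 log units; beyond the scatter) in this assay. Compound 4 is expected to give roughly 5500 nM, within a range from 1800 nM to 16000 nM.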

Compound 4, concentration for 50% growth inhibition: 2700 nM
The estimate for compound 4 lay 2.0-fold (0.31 log units) above the measured number; measured number inside the range.
By their numbers in this assay, from the lowest: compounds 3, 4 and 2 (each within the scatter of the next); then compound 1.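

In this assay, a ring group without oxygen atoms can match one with them: 4-(trifluoromethyl)phenyl replaces 2,3-dihydro-1,4-benzodioxin-2-yl with no change at the digits printed from compound 3 to compound 4 (within the scatter), and replacing 3,4-dimethoxyphenyl gives a 1.3-fold lower number from compound 2 to compound 4 (0.11 log units; within the scatter). Compound 1 alone had suggested that a ring without oxygen atoms goes with a high number, but compound 4 goes against that reading. Both lack oxygen in this group, yet 4-(trifluoromethyl)phenyl in place of 2-chlorophenyl gives a 3.7-fold lower number from compound 1 to compound 4 (0.57 log units; beyond the scatter), so at this position the two oxygen-free groups are not interchangeable.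

The compounds shown leave open whether compound 1 stands apart for its chlorine or for where the chlorine sits, a question that a 4-chlorophenyl group on the same carbon would help to separate. Nothing available here explains why these groups give these numbers.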